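Replacing 4-fluorophenyl with 2,4-dichlorophenyl on a sulfonyl sulfur

The compounds below may be only part of what the source reports. "The series", "measured", "known", "first", "only" and "open" are said of these compounds alone.

In a functional assay on HepG2 cells (Homo sapiens) for antiproliferative activity, read by MTT assay, with a stated time of 48 h (on this read-out higher numbers stand for an effect only at larger amounts of compound and lower numbers for an effect already at smaller amounts), compound 1 `CC1=NN(S(=O)(=O)c2ccccc2)C(c2cc(Br)ccc2O)C1` gives > 60000 nM, which is a limit. In this assay, within the data shown here, compound 2 `CC1=NN(S(=O)(=O)c2ccc(F)cc2)C(c2cc(Br)ccc2O)C1` gives 50100 nM, the only actual number so far. Compound 3 `CC1=NN(S(=O)(=O)c2ccc(Cl)cc2Cl)C(c2cc(Br)ccc2O)C1` differs from it as follows: 2,4-dichlorophenyl in place of 4-fluorophenyl on a sulfonyl sulfur. This puts 2,4-dichlorophenyl in place of 4-fluorophenyl on a sulfonyl sulfur. Among the measured compounds shown here, the one measured step on this same aryl group is an at least 1.1-fold lower number from compound 1 to compound 2 (0.07 log units; that floor lies within the scatter), and it starts from the limit of > 60000 nM in this assay, at which 1 of the 2 values shown sits. It gives no firm direction, so no change beyond the scatter is expected in this assay. The expected step is a 1.4-fold lower number from compound 2 to compound 3 (0.16 log units; within the scatter). Compound 3 is estimated at 35000 nM, with an expected range from 10000 nM to 60000 nM.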

Compound 3, half-maximal effective concentration: 45200 nM
The estimate for compound 3 lay 1.3-fold (0.11 log units) below the measured number; the measured number falls inside the stated range.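

In this assay, the step on this aryl group on the sulfonyl sulfur is a 1.1-fold lower number from compound 2 to compound 3 (0.04 log units; within the scatter), so 2,4-dichlorophenyl and 4-fluorophenyl cannot be told apart at this place. Against phenyl, the reading is an at least 1.3-fold lower number from compound 1 to compound 3 (0.12 log units; that floor lies within the scatter), which also shows no change beyond the scatter. That step gives only a floor, since compound 1 stands at a limit: the limit of > 60000 nM in this assay, at which 1 of the 3 values shown sits.

The compounds shown leave open whether any group on this aryl ring moves the number beyond the scatter. An amine or a carboxylic acid there remains an open case.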